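The source may report more compounds than this note shows. Statements on the series, on what has been measured and on what is new or still open speak of the compounds shown alone.

Measured so far:
Compound 1 `COc1ccc(C2C(O)C(=O)N2c2cc(OC)c(OC)c(OC)c2)cc1`: 13 nM
Compound 2 `CCOc1ccc(C2C(C3CC3)C(=O)N2c2cc(OC)c(OC)c(OC)c2)cc1`: 201 nM
Compound 3 `COc1ccc(C2C(Oc3ccccc3)C(=O)N2c2cc(OC)c(OC)c(OC)c2)cc1`: 19 nM

All three values come from a functional assay on HL-60 cells (Homo sapiens) for inhibition, read by resazurin assay, with a stated time of 72 h; on this read-out lower numbers stand for stronger inhibition and higher numbers for weaker inhibition. On these numbers, compound 3 at 19 nM lies level with compound 1 at 13 nM, since the two sit within the usual scatter of each other. Compound 2 gives a clearly higher number than compound 3.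

The next molecule is compound 4 `CCOc1ccc(C2C(Oc3ccccc3)C(=O)N2c2cc(OC)c(OC)c(OC)c2)cc1`. Its difference from compound 3 is small: methyl in place of hydrogen on a saturated chain carbon bound to an oxygen on an aromatic ring. Read one bond further out, methoxy becomes ethoxy, or 4-methoxyphenyl becomes 4-ethoxyphenyl.

Among the compounds with values here, only one measured step links two compounds here, a 1.5-fold higher number from compound 1 to compound 3 (0.16 log units; within the scatter), and it lies at a different place in the molecule, so it says nothing directly about this change. Compound 2 at 201 nM does carry the ethoxy group, but it also has a cyclopropyl group where compound 3 has its phenoxy group. Its high number therefore cannot be pinned on the ethoxy group alone, and no matched methoxy and ethoxy pair has been measured. It gives only a weak hint towards a higher number, so a small move in that direction is expected in this assay.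

The expected move is a 1.8-fold higher number from compound 3 to compound 4 (0.27 log units; within the scatter).

Compound 4 is expected at about 35 nM, with an estimated range from 10 nM to 120 nM.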

Compound 4, half-maximal inhibitory concentration: 494 nM
Estimate against measurement, compound 4: 14-fold (1.15 log units) below, outside the stated range (above it).
By their numbers in this assay, from the lowest: compounds 1 and 3 (each within the scatter of the next); then compound 2; then compound 4.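

In this assay, within the data shown here, this is the first matched pair for the change from methoxy to ethoxy, and it gives a 26-fold higher number from compound 3 to compound 4 (1.41 log units; beyond the scatter). A single added methyl on the saturated chain carbon bound to an oxygen on an aromatic ring can therefore shift the number far more than its size of one heavy atom might suggest. With ethoxy held fixed, the phenoxy group can also be compared directly with cyclopropyl, and that comparison gives a 2.5-fold higher number from compound 2 to compound 4 (0.39 log units; beyond the scatter), while with methoxy in place, putting phenyl on the oxygen of the hydroxy group gave only a 1.5-fold higher number from compound 1 to compound 3 (0.16 log units; within the scatter). Nothing measured here explains why one methyl matters so much in this molecule.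

The compounds shown leave open whether the same large step would appear with the hydroxy group of compound 1 or the cyclopropyl group of compound 2 instead of phenoxy, since each of those groups is seen with only one of the two ethers. They also leave open how the number would respond to a longer chain such as propoxy, or to an amine such as dimethylamino, in place of the ethoxy group.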